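A few compounds are considered here, and "the series" means these few. Any claim that something is new, unique, unknown or untested is made for them only; others in the source may bear on it.

Values in a functional assay on A549 cells (Homo sapiens) for antiproliferative activity, read by CCK-8 assay, with a stated time of 48 h; on this read-out lower numbers stand for stronger inhibition and higher numbers for weaker inhibition:
- compound 1 `O=C(CCCCCCC(=O)NCCNc1nonc1/C(=N/O)Nc1ccc(F)c(Br)c1)NO`: 36000 nM
- compound 2 `O=C(CCCCC(=O)NCCNc1nonc1/C(=N/O)Nc1ccc(F)c(Br)c1)NO`: > 100000 nM (a limit, not a number)
- compound 3 `Nc1ccccc1NC(=O)c1ccc(C(=O)NCCNc2nonc2/C(=N/O)Nc2ccc(F)c(Br)c2)s1`: 14500 nM
- compound 4 `O=C(CCCC(=O)NCCNc1nonc1/C(=N/O)Nc1ccc(F)c(Br)c1)NO`: not yet measured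

Compound 2 has a limit and no number: the limit of > 100000 nM in this assay, at which 1 of the 3 values shown sits. Moving on to compound 4 is the change (hydroxycarbamoyl in place of (hydroxycarbamoyl)methyl on a saturated chain carbon, three bonds along the chain from a carbonyl carbon), which puts hydroxycarbamoyl in place of (hydroxycarbamoyl)methyl on a saturated chain carbon, three bonds along the chain from a carbonyl carbon. For the measured compounds named here, the one measured step of this kind is an at least 2.7-fold higher number from compound 1 to compound 2 (0.44 log units; beyond the scatter), a shortening of the same chain that went toward weaker inhibition. Going by the values given here, compound 3 lacks this chain and offers no such step. A further move of similar size in the same direction is expected in this assay. The expected step is a step that the limit leaves unreadable from compound 2 to compound 4, and the assay may well report only a limit. For compound 4 the estimate is 200000 nM, with an expected range of 100000 nM to 500000 nM.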

Compound 4, half-maximal inhibitory concentration: > 100000 nM
Compound 4: no number, only a limit; the forecaster's own chance of this, stated with the estimate: 85%; the middle value does not contradict the limit.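

In this assay compound 4 reads > 100000 nM, which is a limit and not a number. Hydroxycarbamoyl in place of 3-(hydroxycarbamoyl)propyl at this chain position gives an at least 2.7-fold higher number from compound 1 to compound 4 (0.44 log units; beyond the scatter), while the step between the two limits cannot be read, so the order of the two shortest chains stays unknown. Shortening the chain beyond compound 1 has now twice given only a limit: the limit of > 100000 nM in this assay, at which 2 of the 4 values shown sit.

Still open, from the compounds shown here alone, is how a chain longer than that of compound 1 would read. Also open, going by these compounds, is whether a carboxylic acid or an amine at the chain end would keep the activity of compound 1.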